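Taking one hydroxy from a weak growth inhibitor

The source may report more compounds than this note shows. Statements on the series, on what has been measured and on what is new or still open speak of the compounds shown alone.

Within the data shown here, in a functional assay on A549 cells (Homo sapiens) for antiproliferative activity, read by MTT assay, with a stated time of 48 h (a higher number here means a weaker inhibitor of growth, a lower number a stronger inhibitor of growth), compound 2 `COC(=O)N1N=C(c2ccccc2)CC1c1ccc(OC)c(O)c1` gives 8930 nM, the only actual number so far. Compound 1 `COC(=O)N1N=C(c2ccccc2)CC1c1ccccc1` reads > 10000 nM, which is a limit of the assay. Compound 3 `COC(=O)N1N=C(c2ccccc2)CC1c1ccc(OC)cc1` is still unmeasured. It has hydrogen in place of hydroxy on an aromatic carbon of compound 2: hydrogen in place of hydroxy on an aromatic carbon. No measured single change is available as a guide. Only a small move towards weaker inhibition in this assay is expected, hardly beyond the scatter, as compound 2 already gives 8930 nM. The estimated change is a 1.3-fold higher number from compound 2 to compound 3 (0.13 log units; within the scatter). For compound 3 the expected value is 12000 nM, with an estimated range from 5000 nM to 28000 nM.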

Compound 3, concentration for 50% growth inhibition: 15300 nM
The estimate for compound 3 lay 1.3-fold (0.11 log units) below the measured number, and the stated range covers the measured number.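

Hydrogen in place of hydroxy on this aromatic carbon, ortho to a methoxy group, gives a 1.7-fold higher number from compound 2 to compound 3 (0.23 log units; within the scatter), so in this assay this hydroxy shows no effect that can be told apart from repeat measurement. Compound 1 reads > 10000 nM, which is a limit of the assay. The step between compound 1 and compound 3 cannot be read, so what the methoxy group adds stays unknown: the limit of > 10000 nM in this assay, at which 1 of the 3 values shown sits.

Still open, on these data alone, is whether an amine or a carboxylic acid at this position, or a longer chain in place of the methoxy group, would shift the number beyond the scatter.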